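Ethynyl for thiophen-2-yl on the shared core

A few compounds are considered here, and "the series" means these few. Any claim that something is new, unique, unknown or untested is made for them only; others in the source may bear on it.

Values in a functional assay on HCT-116 cells (Homo sapiens), read by MTT assay, with a stated time of 72 h (on this read-out higher numbers stand for weaker inhibition and lower numbers for stronger inhibition), so far:
- compound 1 `C#Cc1cn([C@@H]2O[C@H](CO)[C@@H](O)[C@H]2O)c2ncnc(OC)c12` gives 4060 nM as a number
- compound 2 `C#Cc1cn([C@@H]2O[C@H](CO)[C@@H](O)[C@H]2O)c2ncnc(NC)c12` gives > 20000 nM as a limit
- compound 3 `Cc1ncnc2c1c(-c1cccs1)cn2[C@@H]1O[C@H](CO)[C@@H](O)[C@H]1O` gives > 20000 nM as a limit

Compound 3 has no number, and its place is the limit of > 20000 nM in this assay, at which 2 of the 3 values shown sit, in this series. Compound 4 `C#Cc1cn([C@@H]2O[C@H](CO)[C@@H](O)[C@H]2O)c2ncnc(C)c12` carries ethynyl in place of thiophen-2-yl on an aromatic carbon. Within the data shown here, no measured step covers this exchange. The nearest is an at least 4.9-fold higher number from compound 1 to compound 2 (0.69 log units; beyond the scatter) at another place on the core, with ethynyl at both ends, so ethynyl alone does not secure a number. Among the measured compounds shown here, still, compound 1 with 4060 nM is the only compound with a measured number, and it carries ethynyl. A lower number in this assay is therefore expected, of modest size and with a real chance of no number at all. The estimated change is an at least 3.3-fold lower number from compound 3 to compound 4 (0.52 log units; beyond the scatter) in this reading. For compound 4 the expected value is 6000 nM (estimated range 1200 nM to 20000 nM).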

Compound 4, half-maximal inhibitory concentration: > 20000 nM
Compound 4 gave a limit, no number (the forecaster's own chance of this, stated with the estimate: 35%); at least 3.3-fold (0.52 log units) between middle value and limit.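

In this assay the exchange of thiophen-2-yl for ethynyl does not bring compound 4 to a number, so ethynyl at this aromatic carbon is not enough on its own. Methyl in place of methoxy gives an at least 4.9-fold higher number from compound 1 to compound 4 (0.69 log units; beyond the scatter), which leaves compound 1 as the only ethynyl compound shown with a number, and methoxy as the only group on the shared core that goes with one. The steps to compound 4 from compound 3 and from compound 2 cannot be read, since both ends of each are limits: the limit of > 20000 nM in this assay, at which 3 of the 4 values shown sit.

From the compounds shown here alone, it stays open whether ethoxy or an unsubstituted amino group would also give a number alongside ethynyl. Going by these compounds, it also stays open whether thiophen-2-yl would give a number alongside methoxy.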